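The source may report more compounds than this note shows. Statements on the series, on what has been measured and on what is new or still open speak of the compounds shown alone.

Measured so far in a functional assay on MCF7 cells (Homo sapiens) for antiproliferative activity, read by MTT assay, with a stated time of 72 h (a lower number here means a stronger inhibitor, a higher number a weaker inhibitor), are three compounds:
- compound 1 `CN(c1ccccc1)S(=O)(=O)C1CC2OC1C(c1ccc(NC(=O)CCCCCCC(=O)O)cc1)=C2c1ccc(O)cc1` gives 63800 nM
- compound 2 `CCN(c1ccccc1)S(=O)(=O)C1CC2OC1C(c1ccc(NC(=O)CCCCCCC(=O)O)cc1)=C2c1ccc(O)cc1` gives 19100 nM
- compound 3 `CCN(c1ccc(O)cc1)S(=O)(=O)C1CC2OC1C(c1ccc(NC(=O)CCCCCCC(=O)O)cc1)=C2c1ccc(O)cc1` gives 46600 nM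

Compound 3 cannot be told apart from compound 1 (a 1.4-fold lower number from compound 1 to compound 3 (0.14 log units; within the scatter)) and stands above compound 2 (a 2.4-fold higher number from compound 2 to compound 3 (0.39 log units; beyond the scatter)) on these numbers. Compound 4 `CCN(c1ccc(Cl)cc1)S(=O)(=O)C1CC2OC1C(c1ccc(NC(=O)CCCCCCC(=O)O)cc1)=C2c1ccc(O)cc1` is not yet measured and differs from compound 3 by one change: chloro in place of hydroxy on an aromatic carbon. The measured step that bears on this most directly is the modest one that adds the hydroxy (a 2.4-fold higher number from compound 2 to compound 3 (0.39 log units; beyond the scatter)). The other modest step (a 3.3-fold lower number from compound 1 to compound 2 (0.52 log units; beyond the scatter)) concerns the chain on the sulfonamide nitrogen instead. For the measured compounds named here, compound 4 lacks the hydroxy, so a modest move towards compound 2 (19100 nM) is expected, although no measured compound carries chloro. The expected change is a modest drop (a 2.1-fold lower number from compound 3 to compound 4 (0.33 log units; beyond the scatter)) in this assay with wide uncertainty. Compound 4 is estimated at 22000 nM (expected range 9000 nM to 50000 nM).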

Compound 4, half-maximal inhibitory concentration: 22100 nM
The estimate for compound 4 lay 1.0-fold (0.00 log units) below the measured number; the range from low to high includes it.
By their numbers in this assay, from the lowest: compounds 2 and 4 (each within the scatter of the next); then compounds 3 and 1 (each within the scatter of the next).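

In this assay chloro in place of hydroxy on this aromatic carbon lowers the number (a 2.1-fold lower number from compound 3 to compound 4 (0.32 log units; beyond the scatter)), while compound 4 cannot be told apart from compound 2, which has hydrogen there (a 1.2-fold higher number from compound 2 to compound 4 (0.06 log units; within the scatter)). Among the three groups seen at this carbon, hydroxy therefore stands apart, while chloro and hydrogen read alike, a contrast that the earlier compounds could not show with hydrogen and hydroxy alone. The full change from the methyl(phenyl)amino group of compound 1 to the (4-chlorophenyl)(ethyl)amino group also lowers the number beyond the scatter (a 2.9-fold lower number from compound 1 to compound 4 (0.46 log units; beyond the scatter)). No measurement shown here accounts for these differences.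

As far as these compounds go, it remains open whether a methoxy or an amine on this carbon would read with hydroxy or with chloro and hydrogen. The compounds also leave open how a propyl group on the sulfonamide nitrogen would read alongside the chloro.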